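The compounds below may be only part of what the source reports. "The series", "measured", "known", "first", "only" and "open" are said of these compounds alone.

Two compounds have been measured so far in a functional assay on HepG2 cells (Homo sapiens) for cytotoxicity, read by MTT assay, with a stated time of 72 h; a higher number here means a weaker inhibitor, a lower number a stronger inhibitor
compound 1 `[O-][S+](CCCCN=C=S)Cc1ccccc1` gives 2850 nM
compound 2 `[O-][S+](CCCCCN=C=S)Cc1ccccc1` gives 3910 nM

Compound 2 stands level with compound 1 on these numbers, the two values lying within the usual scatter of each other, so no order can be drawn between them.

Compound 3 `[O-][S+](CCCCCCN=C=S)Cc1ccccc1` has not yet been measured. Its difference from compound 2 is a group of 4 heavy atoms (2 carbon, 1 nitrogen, 1 sulfur; no ring) in place of a group of 3 heavy atoms (1 carbon, 1 nitrogen, 1 sulfur; no ring), on a saturated chain carbon, five bonds along the chain from a sulfur and the change sits on a saturated chain carbon, five bonds along the chain from a sulfur. Among the compounds with values here, only one measured step bears on it, a replacement of the same kind on a saturated chain carbon, four bonds along the chain from a sulfur. Since that step was a 1.4-fold higher number from compound 1 to compound 2 (0.14 log units; within the scatter) and nothing else is available for comparison, no change beyond the scatter is expected in this assay for this further replacement. The expected step is a 1.1-fold higher number from compound 2 to compound 3 (0.03 log units; within the scatter) and it remains an estimate. The estimated value for compound 3 is 4200 nM within an expected range of 2100 nM to 8500 nM on present evidence.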

Compound 3, half-maximal inhibitory concentration: 6170 nM
Beside the measured number, compound 3's estimate is 1.5-fold (0.17 log units) below it, and the stated range covers the measured number.
By their numbers in this assay, from the lowest: compounds 1, 2 and 3 (each within the scatter of the next, the first and the last beyond it).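

In this assay, the group of 4 heavy atoms in place of the group of 3 heavy atoms, on a saturated chain carbon, five bonds along the chain from a sulfur, gives a 1.6-fold higher number from compound 2 to compound 3 (0.20 log units; within the scatter), so this single step, like the one before it, does not separate the two compounds it joins. Within the data shown here, what the earlier compounds could not show appears only when the two replacements are taken together: a 2.2-fold higher number from compound 1 to compound 3 (0.34 log units; beyond the scatter), the first difference in this set to pass the scatter, though only a modest one, while compound 2 cannot be told apart from either neighbour. No evidence is available that accounts for this difference.

The compounds shown leave open whether a longer chain would carry the numbers further in the same direction or whether they would level off, as three compounds cannot define a trend beyond their own range. They also leave open how the numbers would respond if an amine or a carboxylic acid stood in place of the group that carries the nitrogen and the sulfur at the end of the chain.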